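Swapping 3-fluorophenyl for 4-cyanophenyl on the shared core

A few compounds are considered here, and "the series" means these few. Any claim that something is new, unique, unknown or untested is made for them only; others in the source may bear on it.

Values in a functional assay on NCI-H460 cells (Homo sapiens) for inhibition, with a stated time of 72 h (a lower number here means a stronger inhibitor, a higher number a weaker inhibitor), for the measured compounds
compound 1 `COc1ccc(S(=O)(=O)N2CCc3cccc(-c4ccc(F)nc4)c32)cc1` gives 135 nM here
compound 2 `COc1ccc(S(=O)(=O)N2CCc3cccc(-c4ccc(F)c(F)c4)c32)cc1` gives 46 nM here
compound 3 `COc1ccc(S(=O)(=O)N2CCc3cccc(-c4cccc(F)c4)c32)cc1` gives 167 nM here

In this assay compound 3 stands at 167 nM in this small set, with a 1.2-fold higher number from compound 1 to compound 3 (0.09 log units; within the scatter) on one side and a 3.6-fold higher number from compound 2 to compound 3 (0.56 log units; beyond the scatter) on the other. Compound 4 `COc1ccc(S(=O)(=O)N2CCc3cccc(-c4ccc(C#N)cc4)c32)cc1` carries 4-cyanophenyl in place of 3-fluorophenyl on an aromatic carbon, a swap counted as 4-cyanophenyl in place of 3-fluorophenyl on an aromatic carbon in full. Within the data shown here, no measured compound holds a nitrile, so only the group swaps at this carbon bear on it, and a 2.9-fold lower number from compound 1 to compound 2 (0.47 log units; beyond the scatter) shows that they can reach a modest size. Their direction does not carry over to a nitrile, so no step beyond the scatter is expected. The estimated move is a 1.7-fold lower number from compound 3 to compound 4 (0.22 log units; within the scatter) and no larger. For compound 4 the estimate is 100 nM with an expected range from 35 nM to 300 nM for now.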

Compound 4, half-maximal inhibitory concentration: 29.5 nM
Beside the measured number, compound 4's estimate is 3.4-fold (0.53 log units) above it, outside the stated range (below it).
By their numbers in this assay, from the lowest: compounds 4 and 2 (each within the scatter of the next); then compounds 1 and 3 (each within the scatter of the next).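

A nitrile at this aromatic carbon gives a 5.7-fold lower number from compound 3 to compound 4 (0.75 log units; beyond the scatter) and a 4.6-fold lower number from compound 1 to compound 4 (0.66 log units; beyond the scatter) in this assay and so opens a route not seen with the earlier groups. Against 3,4-difluorophenyl the change gives a 1.6-fold lower number from compound 2 to compound 4 (0.19 log units; within the scatter) and the two groups cannot be told apart here. Among these compounds, the lowest numbers at this position therefore do not depend on fluoro on the ring, which the earlier compounds could not show. As far as these compounds go, whether 4-aminophenyl or a phenyl bearing a carboxylic acid would hold this level stays open. Nothing at hand accounts for the gain with the nitrile.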